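This account rests on a few compounds, and the source may have more. Where it says the series, first, only, none or still open, it means among the compounds named here.

Measured in a functional assay on HEK293 cells (Homo sapiens) for cytotoxicity; on this read-out higher numbers stand for lower toxicity in this test and lower numbers for higher toxicity in this test:
compound 1 `COc1ccc([C@H]2CC(=O)N(c3cccc(O)c3)C2)cc1OC1CCCC1`: > 10000 nM
compound 2 `COc1ccc([C@H]2CC(=O)N(c3cccc(N)c3C)C2)cc1OC1CCCC1`: > 10000 nM
compound 3 `COc1ccc([C@H]2CC(=O)N(c3ccc([S+](C)[O-])cc3)C2)cc1OC1CCCC1`: 7510 nM

Compound 1 gives > 10000 nM, which is a limit of the assay and not a number. Compound 2 gives > 10000 nM, which is also a limit. Together they make up (the limit of > 10000 nM in this assay, at which 2 of the 3 values shown sit). Compound 3 alone gives a number, 7510 nM.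

The next compound, compound 4 `COc1ccc([C@H]2CC(=O)N(c3cccc(NCc4ccoc4)c3)C2)cc1OC1CCCC1`, keeps the core of compound 1 and carries ((furan-3-yl)methyl)amino in place of hydroxy on an aromatic carbon, meta to a large group: ((furan-3-yl)methyl)amino in place of hydroxy on an aromatic carbon.

Among the measured compounds shown here, no measured step makes this exact change, but two steps alter the same aromatic group on the amide-type nitrogen. The change to compound 2 is a step that the two limits leave unreadable from compound 1 to compound 2. The change to compound 3 is an at least 1.3-fold lower number from compound 1 to compound 3 (0.12 log units; that floor lies within the scatter). Neither step therefore offers a readable size to carry over, and the measured values of compound 2 and compound 3 give no sign of a large move in this assay.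

No step beyond the scatter is expected, in either direction, and the expected change is a number no higher from compound 1 to compound 4 (the limit leaves the size open). Compound 4 may well return only a limit. For compound 4 the estimate is 10000 nM, with an expected range from 4000 nM to 25000 nM.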

Compound 4, half-maximal cytotoxic concentration: > 10000 nM
Compound 4: only a limit was reported; the forecaster's own chance of this, stated with the estimate: 60%; the middle value lies on the limit itself.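

In this assay compound 4 gives > 10000 nM, which is a limit of the assay and not a number. Compound 1 also stands at a limit, so no step between compound 1 and compound 4 can be read: the limit of > 10000 nM in this assay, at which 3 of the 4 values shown sit.

The compounds shown leave open whether ((furan-3-yl)methyl)amino in place of hydroxy changes this read-out at all.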